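A few compounds are considered here, and "the series" means these few. Any claim that something is new, unique, unknown or untested is made for them only; others in the source may bear on it.

In a functional assay on HCT-116 cells (Homo sapiens) for inhibition, read by MTT assay, with a stated time of 48 h (on this read-out higher numbers stand for weaker inhibition and lower numbers for stronger inhibition), compound 1 `COc1cc(-c2cc(-c3ccc(Cl)cc3)nc(-c3ccccc3)n2)cc(OC)c1OC` gives 7980 nM and compound 2 `COc1cc(-c2cc(-c3ccc(Br)cc3)nc(-c3ccccc3)n2)cc(OC)c1OC` gives 4320 nM. These two values lie within the usual scatter of each other, so compound 2 cannot be ranked apart from compound 1. The next structure, compound 3 `COc1cc(-c2cc(-c3cccc([N+](=O)[O-])c3)nc(-c3ccccc3)n2)cc(OC)c1OC`, has 3-nitrophenyl in place of 4-bromophenyl on an aromatic carbon of the shared core (3-nitrophenyl in place of 4-bromophenyl on an aromatic carbon). Going by the values given here, only one measured step bears on this change: a 1.8-fold lower number from compound 1 to compound 2 (0.27 log units; within the scatter), with bromo in place of chloro on an aromatic carbon. Among the compounds with values here, that step stays within the scatter, but it exchanges one halogen for another, and no measured compound carries 3-nitrophenyl, so it is only a weak guide. In this assay the expected step is a 1.2-fold higher number from compound 2 to compound 3 (0.06 log units; within the scatter), with no firm direction and nothing expected beyond the scatter. For compound 3 the estimated value is 5000 nM, with an expected range from 1500 nM to 15000 nM.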

Compound 3, half-maximal inhibitory concentration: > 25000 nM
Compound 3: no number, only a limit; the forecaster's own chance of this, stated with the estimate: 5%; at least 5.0-fold (0.69 log units) between middle value and limit.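

In this assay, replacing 4-bromophenyl with 3-nitrophenyl gives an at least 5.7-fold higher number from compound 2 to compound 3 (0.76 log units; beyond the scatter), and replacing 4-chlorophenyl with 3-nitrophenyl gives an at least 3.1-fold higher number from compound 1 to compound 3 (0.49 log units; beyond the scatter). Going by these compounds alone, the exchange of one halogen for another stayed within the scatter, so only this new change shows that inhibition at this position of the shared core, next to the ring nitrogen, can weaken clearly when the aromatic group changes. The reading for compound 3 is a limit of the assay and not a number, so the full size of the weakening stays unknown: the limit of > 25000 nM in this assay, at which 1 of the 3 values shown sits.

The nitro group and its place on the phenyl ring change together here, so the compounds shown cannot tell which of the two matters. A 4-nitrophenyl or a 3-bromophenyl group would separate these two changes, and a 4-aminophenyl group would test a different kind of substituent at the same position.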